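The source may report more compounds than this note shows. Statements on the series, on what has been measured and on what is new or still open speak of the compounds shown alone.

Compound 1 `Oc1ccc(-c2cc(-c3ccsc3)cc(-c3ccc(O)cc3)n2)cc1` gives 2060 nM in a functional assay on DU-145 cells (Homo sapiens) for cytotoxicity, read by CCK-8 assay; a higher number here means a weaker inhibitor, a lower number a stronger inhibitor.
Compound 2 `Oc1ccc(-c2cc(-c3ccco3)cc(-c3ccc(O)cc3)n2)cc1` reaches only the limit of this assay, > 50000 nM.
Compound 3 `Oc1ccc(-c2cc(-c3ccoc3)cc(-c3ccccc3O)n2)cc1` gives 28000 nM in this assay.

Compound 3 stands highest of the two numbers that this assay has produced, and compound 1 is its nearest neighbour with a much lower number; the third value, that of compound 2, is a limit and not a number. The unmeasured compound 4 `Oc1ccc(-c2cc(-c3ccoc3)cc(-c3ccc(O)cc3)n2)cc1` keeps every atom of compound 3 but joins them differently: 4-hydroxyphenyl in place of 2-hydroxyphenyl on an aromatic carbon.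

Going by the values given here, no measured step touches the hydroxyphenyl group. Among the compounds with values here, the one step in this assay changes the five-membered ring instead, and it was large: an at least 24-fold higher number from compound 1 to compound 2 (1.38 log units; beyond the scatter), ending at the limit (the limit of > 50000 nM in this assay, at which 1 of the 3 values shown sits). Compound 3 and compound 4 both carry furan-3-yl, so that step does not tell how the hydroxyl position alone shifts the number. The comparison between compound 1 and compound 3 mixes two changes and cannot be separated either.

The expectation for compound 4 therefore rests on thin ground and is drawn wide. The estimate for compound 4 in this assay is 12000 nM, between 3000 nM and 45000 nM, which would mean the step of a 2.3-fold lower number from compound 3 to compound 4 (0.37 log units; beyond the scatter), expected to lie within or only a little beyond the scatter.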

Compound 4, half-maximal inhibitory concentration: 3440 nM
The estimate for compound 4 lay 3.5-fold (0.54 log units) above the measured number; low and high end bracket the measured number.
By their numbers in this assay, from the lowest: compounds 1 and 4 (each within the scatter of the next); then compound 3. At a limit, above all of these: compound 2.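

In this assay, going by these compounds alone, the step of an 8.1-fold lower number from compound 3 to compound 4 (0.91 log units; beyond the scatter) is the first to change the hydroxyphenyl group alone, and it shows that the number responds to where the hydroxyl sits on the phenyl ring next to the ring nitrogen, with 4-hydroxyphenyl giving the lower number. With 4-hydroxyphenyl held constant, the step of an at least 14-fold lower number from compound 2 to compound 4 (1.16 log units; beyond the scatter) shows that the attachment point of the furan also matters, although the starting value for compound 2 is a limit and not a number: the limit of > 50000 nM in this assay, at which 1 of the 4 values shown sits. The step of a 1.7-fold higher number from compound 1 to compound 4 (0.22 log units; within the scatter) shows no separation between furan-3-yl and thiophen-3-yl in this assay, so the loss seen with furan-2-yl goes with that particular ring attachment and not with furan as such.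

From the compounds shown here alone, what 3-hydroxyphenyl would give at this position remains open, as does the result of replacing the hydroxyl with an amine or a methoxy group. Also open, going by these compounds, is whether the other 4-hydroxyphenyl group, meta to this position, responds in the same way to such changes.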